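The source may report more compounds than this note shows. Statements on the series, on what has been measured and on what is new or still open speak of the compounds shown alone.

Compound 1, `O=C1c2ccccc2C(=O)N1CNc1ccc(F)cc1`, in an assay on isolated protein for inhibition of ribosomal protein S6 kinase alpha-2 (Homo sapiens), read by fluorescence, with a stated time of 20 min, tested at 10 uM (on this read-out higher numbers stand for more inhibition at the one concentration tested (going by the name of the read-out) and lower numbers for less inhibition), compound 1 gives 56.7%.
Compound 2, `COc1ccc(NCN2C(=O)c3ccccc3C2=O)cc1`, gives 97.2%.
Compound 3, `COc1ccc(N(C)CN2C(=O)c3ccccc3C2=O)cc1`, gives 87%.

Compound 2 stands highest of the three numbers; the nearest other value lies a number 10.2 percentage points lower from compound 2 to compound 3 (beyond the scatter), the furthest a number 40.5 percentage points higher from compound 1 to compound 2 (beyond the scatter). Compound 4 is `COc1ccc(NCN2C(=O)c3ccc(N)cc3C2=O)cc1`; it differs from compound 2 by amino in place of hydrogen on an aromatic carbon. Neither measured step bears on this change: the step of a number 40.5 percentage points higher from compound 1 to compound 2 (beyond the scatter) altered a group on the other aromatic ring, and the step of a number 10.2 percentage points lower from compound 2 to compound 3 (beyond the scatter) altered a nitrogen, so nothing here reports a change on the core of compound 2. With the number for compound 2 already near the top of the scale, any step in this assay is expected to be small or within the scatter, with more room downward than upward. For compound 4 the expected value is 90%, ranging from 70% to 100%, an expected step of a number 7.2 percentage points lower from compound 2 to compound 4 (within the scatter).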

Compound 4, a percentage reported as inhibition, at one concentration (the size of the read-out at that concentration, not a potency): 109%
For compound 4 the middle estimate is 19 percentage points below the measured one, and the stated range ends below it.
By their numbers in this assay, from the lowest: compound 1; then compound 3; then compound 2; then compound 4.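

Amino in place of hydrogen on the core gives a number 11.8 percentage points higher from compound 2 to compound 4 (beyond the scatter) in this assay, so this aromatic carbon of the core accepts a substituent with no loss of inhibition. This is the first change on the core among these compounds, and it shows that a reading as high as that of compound 2 could still rise. Nothing measured here accounts for the rise.

As far as these compounds go, whether a hydroxyl or a carboxylic acid on this carbon would behave like amino remains open. So does whether amino would give a similar step with fluoro in place of methoxy on the other ring.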